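From Methoxy to Chloro on a Shared Core

The source may hold more compounds than are shown below. What is called first, only, known or untested is meant among the compounds shown, and "the series" means these compounds.

In a functional assay on SGC-7901 cells (Homo sapiens) for antiproliferative activity, read by MTT assay, with a stated time of 48 h (on this read-out lower numbers stand for stronger inhibition and higher numbers for weaker inhibition), compound 1 (`COc1ccccc1-c1nnc(SCc2ccc(Cl)nc2)o1`) gives 8.2 ug/mL while compound 2 (`COc1ccc(-c2nnc(SCc3ccc(Cl)nc3)o2)cc1`) gives 3.5 ug/mL and so holds the lower of the two numbers, a gap beyond the usual scatter. Compound 3 (`Clc1ccc(-c2nnc(SCc3ccc(Cl)nc3)o2)cc1`) carries chloro in place of methoxy on an aromatic carbon para to a large group. Among the compounds with values here, no measured pair tests this swap, so no step beyond the scatter is expected in this assay (a 1.1-fold higher number from compound 2 to compound 3 (0.06 log units; within the scatter)). For compound 3 the estimated half-maximal inhibitory concentration is 4 ug/mL (expected range 1.5 ug/mL to 10 ug/mL).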

Compound 3, half-maximal inhibitory concentration: 8.62 ug/mL
Compound 3: middle estimate off by 2.2-fold (0.33 log units), on the low side; measured number inside the range.
By their numbers in this assay, from the lowest: compound 2; then compounds 1 and 3 (each within the scatter of the next).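

In this assay this position turns out to be sensitive to what it carries: chloro in place of methoxy on an aromatic carbon, para to a large group, gives a 2.5-fold higher number from compound 2 to compound 3 (0.39 log units; beyond the scatter) and that step is modest but beyond the scatter. On this read-out, then, chloro does not serve as a neutral replacement for methoxy at this place. Nothing available accounts for the step.

On these data alone, whether an amine, a hydroxyl or a fluoro at this same place would match methoxy or improve on it remains open. So does whether a longer chain, such as ethoxy, would keep the lower number of compound 2.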